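Chloro for fluoro in a bis-arylidene piperidinone pair

This account rests on a few compounds, and the source may have more. Where it says the series, first, only, none or still open, it means among the compounds named here.

Compound 1 `CN1C/C(=C\c2ccc(F)cc2)C(=O)/C(=C/c2cccc([N+](=O)[O-])c2)C1` gives 6250 nM in a functional assay on HeLa cells (Homo sapiens) for cytotoxicity, read by MTT assay, with a stated time of 24 h; on this read-out lower numbers stand for stronger inhibition and higher numbers for weaker inhibition. Compound 2 `CN1C/C(=C\c2ccc(Cl)cc2)C(=O)/C(=C/c2cccc([N+](=O)[O-])c2)C1` reaches only a limit of the assay, > 20000 nM, in this assay. Compound 3 `CN1C/C(=C\c2ccc(F)cc2)C(=O)/C(=C/c2ccc(C#N)cc2)C1` gives 10200 nM in this assay; the difference between the cores of compound 1 and compound 3 is not broken down here. The change chloro in place of fluoro on an aromatic carbon made a step of an at least 3.2-fold higher number from compound 1 to compound 2 (0.50 log units; beyond the scatter), its size set by the limit of > 20000 nM in this assay, at which 1 of the 3 values shown sits. Compound 4 `CN1C/C(=C\c2ccc(Cl)cc2)C(=O)/C(=C/c2ccc(C#N)cc2)C1` is unmeasured and carries the same kind of change against compound 3, (chloro in place of fluoro on an aromatic carbon). Starting from compound 3, a step of about a 2.9-fold higher number from compound 3 to compound 4 (0.47 log units; beyond the scatter) is expected in this assay, resting on compound 1 to compound 2 giving an at least 3.2-fold higher number from compound 1 to compound 2 (0.50 log units; beyond the scatter). Compound 4 is estimated at 30000 nM, likely beyond the measurable range.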

Compound 4, half-maximal inhibitory concentration: 11200 nM
Estimate against measurement, compound 4: 2.7-fold (0.43 log units) above; measured number outside the range, below it.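

The change from 4-fluorophenyl to 4-chlorophenyl gives a 1.1-fold higher number from compound 3 to compound 4 (0.04 log units; within the scatter) in this assay, so the step seen on the core of compound 1 does not carry over at its size to this core: the same change on two cores in this assay, an at least 3.2-fold higher number (0.50 log units; beyond the scatter) from compound 1 to compound 2 and a 1.1-fold higher number (0.04 log units; within the scatter) from compound 3 to compound 4, at least 2.9-fold (0.46 log units) apart, beyond the scatter of two such steps. Compound 2 gives only a limit of the assay, > 20000 nM, so the earlier step and the gap between the steps are bounds rather than exact sizes: the limit of > 20000 nM in this assay, at which 1 of the 4 values shown sits. The size of this change therefore differs between these two cores, but two pairs give no rule for other cores and do not show which feature of the cores matters.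

Open, from the compounds shown here alone, is how the change behaves when an amine or a carboxylic acid replaces the nitro or nitrile group on the other aromatic ring. Also open, going by these compounds, is whether bromo in place of chloro would follow the same course on both cores.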